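The source may report more compounds than this note shows. Statements on the series, on what has been measured and on what is new or still open speak of the compounds shown alone.

Measured in an assay on cells for agonist activity at vitamin D3 receptor (Homo sapiens), with a stated time of 96 h; a lower number here means that less compound is needed, a higher number that more compound is needed for the effect:
compound 1 `CCn1c(C(=O)NCCN(C)C)ccc1C(CC)(CC)c1ccc(OCCC(O)(CC)CC)c(C)c1` — 82 nM
compound 2 `CCn1c(C(=O)Nc2ccc(OC(F)(F)F)cc2)ccc1C(CC)(CC)c1ccc(OCCC(O)(CC)CC)c(C)c1` — > 10000 nM, a limit of the assay
compound 3 `CCOc1ccc(NC(=O)c2ccc(C(CC)(CC)c3ccc(OCCC(O)(CC)CC)c(C)c3)n2CC)cc1` — 1630 nM

Compound 1 gives the lowest of the two numbers; the nearest is compound 3, reached by a 20-fold higher number from compound 1 to compound 3 (1.30 log units; beyond the scatter). For compound 2 only a limit is reported (the limit of > 10000 nM in this assay, at which 1 of the 3 values shown sits), and an at least 120-fold higher number from compound 1 to compound 2 (2.08 log units; beyond the scatter) is the larger of the two steps. Both measured steps replace the 2-(dimethylamino)ethyl group on the amide-type nitrogen with an aromatic ring, and both move strongly to higher numbers. Compound 4 `CCOC(=O)CN(C)C(=O)c1ccc(C(CC)(CC)c2ccc(OCCC(O)(CC)CC)c(C)c2)n1CC` differs from compound 1 by ((ethoxycarbonyl)methyl)(methyl)amino in place of (2-(dimethylamino)ethyl)amino on a carbonyl carbon; here no ring enters, unlike in the two aryl steps, so the weight of those steps transfers only in part. A step of a 4.9-fold higher number from compound 1 to compound 4 (0.69 log units; beyond the scatter) towards a higher number is expected, smaller than either aryl step. Compound 4 is estimated at 400 nM, range 120 nM to 1500 nM.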

Compound 4, half-maximal effective concentration: 520 nM
Beside the measured number, compound 4's estimate is 1.3-fold (0.11 log units) below it, within the range that was stated.
By their numbers in this assay, from the lowest: compound 1; then compound 4; then compound 3. At a limit, above all of these: compound 2.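

The carbonyl carbon accepts a non-aromatic group with no hydrogen-bond donor and no dimethylamino group at only a modest cost, with a 6.3-fold higher number from compound 1 to compound 4 (0.80 log units; beyond the scatter). Without a ring in the group, compound 4 also sits lower than both aryl amides, with a 3.1-fold lower number from compound 3 to compound 4 (0.50 log units; beyond the scatter) and an at least 19-fold lower number from compound 2 to compound 4 (1.28 log units; beyond the scatter). The value of compound 2 is a limit of the assay: the limit of > 10000 nM in this assay, at which 1 of the 4 values shown sits.

From the compounds shown here alone, the change removes the amide hydrogen and the dimethylamino group and adds the ethoxycarbonyl group at once, so the share of each stays open. Also open, going by these compounds, is how a carboxylic acid in place of the ethyl ester, or a morpholine on the same carbonyl carbon, would read.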